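From Bromo to 3-Fluorophenyl: A Step Without a Baseline

The source may report more compounds than this note shows. Statements on the series, on what has been measured and on what is new or still open speak of the compounds shown alone.

In a functional assay on HepG2 cells (Homo sapiens) for cytotoxicity, read by sulforhodamine B assay, with a stated time of 48 h (a higher number here means a weaker inhibitor, a lower number a stronger inhibitor), compound 2 `COc1ccc(/C=C/C(=O)c2cccc(Br)c2)cc1OC` has no single number to its name, and its entry reads "not determined" (no result reported). Compound 3 `COc1ccc(/C=C/C(=O)c2cccc(Br)c2)cc1` is in the same position, with the entry "not determined" (no result reported). For the measured compounds named here, the only number in this small set belongs to compound 1 `COc1ccc(/C=C/C(=O)c2ccc(NC(C)=O)c(-c3ccc(F)cc3)c2)cc1OC`, which gives 5630 nM.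

The next compound to be tested is compound 4 `COc1ccc(/C=C/C(=O)c2cccc(-c3cccc(F)c3)c2)cc1OC`. The structural change is 3-fluorophenyl in place of bromo on an aromatic carbon. In words, 3-fluorophenyl takes the place of bromo on an aromatic carbon, meta to a large group.

With no number for compound 2, no measured starting point exists, so the size of this step in this assay cannot be read from the data. The expectation is for no step beyond the scatter, with no favoured direction. Going by the values given here, the only guide to the level of compound 4 is compound 1 at 5630 nM, which also carries a fluorophenyl group but differs from compound 4 in other places. That makes it a loose guide, and the range has to stay wide. Compound 4 is expected at about 8000 nM, with an estimated range of 2500 nM to 25000 nM.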

Compound 4, half-maximal inhibitory concentration: 1170 nM
Compound 4: the middle estimate sits 6.8-fold (0.83 log units) above what was measured; measured number below the stated range.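

In this assay compound 4 gives 1170 nM but compound 2 has no single number to set against it, so no step can be read from this pair. No measured evidence is available to explain the value of compound 4. Going by these compounds, what replacing bromo with 3-fluorophenyl does on its own to activity stays open.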